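The source may report more compounds than this note shows. Statements on the series, on what has been measured and on what is new or still open speak of the compounds shown alone.

Series notes, chain-end variation.

Three compounds of the shared core are in hand. Compound 1 `Cc1c(OCCCCOc2cccc(F)c2F)ccc(C(=O)CC(C)C)c1O` gives 384 nM in a functional assay for binding affinity to metabotropic glutamate receptor 2 (Homo sapiens), read by GTPgammaS binding (a lower number here means that less compound is needed, a higher number that more compound is needed for the effect), the lowest of the three numbers. Compound 3 `CC(C)CC(=O)c1ccc(OCCCCOc2cccc(F)c2F)c(Br)c1O` gives 558 nM, and the step of a 1.5-fold higher number from compound 1 to compound 3 (0.16 log units; within the scatter) lies within the scatter. Compound 2 `CC(C)CC(=O)c1ccc(OCCCCOc2ccccc2)c(Br)c1O` gives 1500 nM, the highest of the three; the step of a 2.7-fold lower number from compound 2 to compound 3 (0.43 log units; beyond the scatter) is the only one beyond the scatter, and it concerns the aryl group at the far end of the chain.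

Compound 4 `Cc1c(OCCCCSc2ccccn2)ccc(C(=O)CC(C)C)c1O` is not yet measured. Relative to compound 1 the change is (pyridin-2-yl)sulfanyl in place of 2,3-difluorophenoxy on a saturated chain carbon, four bonds along the chain from an oxygen on an aromatic ring. For the measured compounds named here, the one measured step that bears on this position is a 2.7-fold lower number from compound 2 to compound 3 (0.43 log units; beyond the scatter), which shows that taking the two fluorines off the distal ring raises the number modestly. Going by the values given here, compound 4 also drops the fluorines, and on top of that exchanges the oxygen for sulfur and the carbon-only ring for one with a nitrogen; for those two parts of the change no measured step exists. On the strength of the fluorine loss alone, compound 4 is expected to move from compound 1 by a 2.3-fold higher number from compound 1 to compound 4 (0.37 log units; beyond the scatter). The estimate for compound 4 in this assay is therefore 900 nM, with a range of 350 nM to 2500 nM.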

Compound 4, half-maximal effective concentration: 1530 nM
Compound 4: middle estimate off by 1.7-fold (0.23 log units), on the low side; low and high end bracket the measured number.
By their numbers in this assay, from the lowest: compounds 1 and 3 (each within the scatter of the next); then compounds 2 and 4 (each within the scatter of the next).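

In this assay, for the compounds shown here, the step of a 4.0-fold higher number from compound 1 to compound 4 (0.60 log units; beyond the scatter) is the first measured change at the chain end on the core of compound 1, since the earlier step at this position was read on the bromo-bearing core. It is also the first to change the linking atom and the ring atoms together, and here (pyridin-2-yl)sulfanyl in place of 2,3-difluorophenoxy gives a number beyond the scatter, so this position responds to more than one kind of exchange on both cores. This single step cannot be divided among the loss of the two fluorines, the sulfur and the ring nitrogen, and no supporting measurement bears on why the number rises.

The compounds shown leave open what the sulfur and the ring nitrogen each contribute, which a phenylsulfanyl or a pyridin-2-yloxy group on the same chain would help to separate. Also open, as far as these compounds go, is how the number responds to an amine or a carboxylic acid at the chain end, or to a longer chain.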